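Sulfone series: one fluorine removed from compound 2

The compounds below may be only part of what the source reports. "The series", "measured", "known", "first", "only" and "open" are said of these compounds alone.

The series pairs a benzylic amide of a bicyclic heteroaryl acid with an aryl sulfone, and activity is read in a functional assay on A2780 cells (Homo sapiens) for inhibition, read by sulforhodamine B assay, with a stated time of 72 h; on this read-out higher numbers stand for weaker inhibition and lower numbers for stronger inhibition. Compound 1 `O=C(NCc1ccc(S(=O)(=O)c2cc(F)cc(F)c2)cc1)c1cc2ccncc2o1` gives 9 nM in this assay. Compound 2 `O=C(NCc1ccc(S(=O)(=O)c2ccc(F)c(F)c2)cc1)c1cc2cnccc2[nH]1` gives 14 nM in this assay. Of the two numbers shown, compound 2 gives the higher one, but the gap to compound 1 is within the scatter, so the two cannot be told apart. Compound 3 `O=C(NCc1ccc(S(=O)(=O)N2CCCCC2)cc1)c1ccc2nc[nH]c2c1`, which carries a piperidine sulfonamide in place of the aryl sulfone, reaches only a limit of this assay, > 10000 nM. Among the measured compounds shown here, that reading is the one value at the limit of > 10000 nM in this assay, at which 1 of the 3 values shown sits, and it stands apart from the two numbers with a difluorophenyl sulfone.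

Compound 4 `O=C(NCc1ccc(S(=O)(=O)c2cccc(F)c2)cc1)c1cc2cnccc2[nH]1` is not yet measured in this assay. It differs from compound 2 by hydrogen in place of fluoro on an aromatic carbon; the same change, read one bond further out, is 3,4-difluorophenyl to 3-fluorophenyl. For the measured compounds named here, no measured pair in the set isolates this change, so its size is open. A small step, no more than the scatter or slightly beyond it toward a weaker number, is expected for the change from compound 2 to compound 4 in this assay, a 1.8-fold higher number from compound 2 to compound 4 (0.25 log units; within the scatter). Compound 4 is therefore expected to give about 25 nM in this assay, within a range of 8 nM to 80 nM.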

Compound 4, half-maximal inhibitory concentration: 11 nM
Compound 4: the middle estimate sits 2.3-fold (0.36 log units) above what was measured; measured number inside the range.
By their numbers in this assay, from the lowest: compounds 1, 4 and 2 (each within the scatter of the next). At a limit, above all of these: compound 3.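

In this assay the change from 3,4-difluorophenyl to 3-fluorophenyl reads as a 1.3-fold lower number from compound 2 to compound 4 (0.10 log units; within the scatter) and so gives the series its first step confined to one place. At this aromatic carbon, para to a large group, hydrogen in place of fluoro brings no change that can be told from the scatter, so the fluoro group at this position is not required for a low nanomolar reading. No measurement shown bears on why this step is so small.

Still open, on these data alone, is whether the remaining fluoro group can also go, leaving a plain phenyl sulfone, and whether a larger group at the same carbon, such as methoxy, an amine or a carboxylic acid, would keep the reading in this range. Compound 3 gives > 10000 nM in this assay as a limit, and it differs from compound 2 in more than one place, so the contribution of the piperidine sulfonamide alone remains unresolved.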